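This account rests on a few compounds, and the source may have more. Where it says the series, first, only, none or still open, it means among the compounds named here.

Measured so far, in a functional assay on the whole organism for positive allosteric modulation, with Rattus norvegicus as the target; a lower number here means that less compound is needed, a higher number that more compound is needed for the effect:
- compound 1, `Cc1nn(C)c2c1C(c1cccc(Cl)c1)=NCCN2`, gives 0.63 mg/kg
- compound 2, `Cc1nn(C)c2c1C(c1cccc(C(F)(F)F)c1)=NCCN2`, gives 0.63 mg/kg
- compound 3, `Cc1nn(C)c2c1C(c1cccc(C#N)c1)=NCCN2`, gives 1.25 mg/kg

All three compounds share one core and differ only in the group on the pendant benzene ring. Compound 3 has the highest number of the three, but its distance to the others is small: the step of a 2.0-fold higher number from compound 1 to compound 3 (0.30 log units; within the scatter) and the step of a 2.0-fold higher number from compound 2 to compound 3 (0.30 log units; within the scatter) both lie within the scatter, as does the step of no change at the digits printed from compound 1 to compound 2 (within the scatter). On these numbers, then, the three compounds cannot be told apart with any confidence.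

Compound 4, `Cc1nn(C)c2c1C(c1cccc(N=[N+]=[N-])c1)=NCCN2`, is not yet measured. It differs from compound 3 as follows: azido in place of cyano on an aromatic carbon.

Among the compounds with values here, no measured step swaps the cyano for an azido group, so the expectation rests on the three swaps already seen at the same position, each of which changed the number by no more than the scatter. The change to compound 4 is therefore expected to give a step of a 1.3-fold lower number from compound 3 to compound 4 (0.10 log units; within the scatter), that is, nothing beyond the scatter, in either direction. Compound 4 is estimated at 1 mg/kg, with a plausible range from 0.4 mg/kg to 2.5 mg/kg.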

Compound 4, minimum effective dose: 2.5 mg/kg
The estimate for compound 4 lay 2.5-fold (0.40 log units) below the measured number, and the stated range covers the measured number.
By their numbers in this assay, from the lowest: compounds 1, 2, 3 and 4 (each within the scatter of the next, the first and the last beyond it).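

Within the data shown here, at this position on the benzene ring, the azido group gives the first steps in this assay that pass the scatter, with a 4.0-fold higher number from compound 1 to compound 4 (0.60 log units; beyond the scatter) and a 4.0-fold higher number from compound 2 to compound 4 (0.60 log units; beyond the scatter) as the two cases, so the choice of group here can matter in this small set. The picture is graded rather than split into two clear camps, as a 2.0-fold higher number from compound 3 to compound 4 (0.30 log units; within the scatter) stays within the scatter and the cyano compound cannot be separated from the chloro, trifluoromethyl or azido compounds; only the two ends of this series differ. Nothing available gives a reason for these steps.

The compounds shown leave open where a plain hydrogen, an amine or a carboxylic acid at this same place would fall relative to compound 1, compound 2 and compound 4. They also leave open whether a longer chain, such as an ethyl or propyl group, would lie within the scatter of these four compounds or beyond it.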